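A few compounds are considered here, and "the series" means these few. Any claim that something is new, unique, unknown or untested is made for them only; others in the source may bear on it.

Three compounds built on the same core differ only in the ring attached to a saturated chain carbon bound to an aromatic nitrogen. In a functional assay on MCF7 cells (Homo sapiens) for inhibition, read by MTT assay, with a stated time of 48 h, tested at 10 uM (a lower number here means less inhibition of growth, a higher number more inhibition of growth at the concentration tested), compound 1 `O=C(/C=C/c1ccc(OCc2cn(Cc3ccccc3Br)nn2)cc1)c1ccc([N+](=O)[O-])cc1` gives 43%, compound 2 `O=C(/C=C/c1ccc(OCc2cn(Cc3cccc(Br)c3)nn2)cc1)c1ccc([N+](=O)[O-])cc1` gives 12%, and compound 3 `O=C(/C=C/c1ccc(OCc2cn(Cc3ccc(Br)cc3)nn2)cc1)c1ccc([N+](=O)[O-])cc1` gives 18%. Compound 3 thus stands second highest of the three: the step of a number 6 percentage points higher from compound 2 to compound 3 (within the scatter) lies within the scatter, so compounds 2 and 3 cannot be told apart, whereas a number 25 percentage points lower from compound 1 to compound 3 (beyond the scatter) is beyond it.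

Compound 4 `O=C(/C=C/c1ccc(OCc2cn(Cc3ccccc3F)nn2)cc1)c1ccc([N+](=O)[O-])cc1` is the next step from compound 3: 2-fluorophenyl in place of 4-bromophenyl on a saturated chain carbon bound to an aromatic nitrogen. Within the data shown here, two measured steps bear on it. a number 25 percentage points lower from compound 1 to compound 3 (beyond the scatter) shows that exchanging 2-bromophenyl for 4-bromophenyl lowered inhibition by a modest amount, and a number 31 percentage points lower from compound 1 to compound 2 (beyond the scatter) shows a large drop for 3-bromophenyl. The group names 2-fluorophenyl and 2-bromophenyl differ only in the halogen, so the reverse of the step from compound 1 to compound 3 points to a rise. Among the measured compounds shown here, no measured pair, however, exchanges bromine for fluorine, so the size of that rise is uncertain and only a broad range can be given. The expected step is a number 14 percentage points higher from compound 3 to compound 4 (beyond the scatter). Compound 4 is accordingly estimated at 32% in this assay, with a range from 12% to 50%.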

Compound 4, percent growth inhibition at one concentration: 33%
Beside the measured number, compound 4's estimate is 1 percentage points below it; low and high end bracket the measured number.
By their numbers in this assay, from the lowest: compounds 2 and 3 (each within the scatter of the next); then compounds 4 and 1 (each within the scatter of the next).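

Among these compounds, the step of a number 10 percentage points lower from compound 1 to compound 4 (within the scatter) is the first direct exchange of one halogen for another in this set, fluoro in place of bromo on an aromatic carbon, and in this assay it leaves the 2-fluorophenyl and 2-bromophenyl compounds indistinguishable. The steps of a number 15 percentage points higher from compound 3 to compound 4 (beyond the scatter) and a number 21 percentage points higher from compound 2 to compound 4 (beyond the scatter) are both beyond the scatter, so among these four compounds the two groups numbered 2 in their names both read higher than 3-bromophenyl and 4-bromophenyl, and the higher reading no longer rests on a single bromine compound. The data hold no independent measurement that could explain this difference on a saturated chain carbon bound to an aromatic nitrogen.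

The compounds shown leave open whether 3-fluorophenyl and 4-fluorophenyl would read as low as their bromine counterparts, which would show whether the numbering in the group name matters for fluorine as it does for bromine. They also leave open how a 2-chlorophenyl, 2-methoxyphenyl or 2-aminophenyl group would compare with the two halogens tested in this same place.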